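The source may report more compounds than this note shows. Statements on the series, on what has been measured and on what is new or still open speak of the compounds shown alone.

Compound 1: `Cc1cc(=O)n([C@@H]2O[C@H](COP(=O)(O)OP(=O)(O)OP(=O)(O)O)[C@@H](O)[C@H]2O)c(=O)[nH]1`. In an in vitro functional assay on 1321-N1 cells for agonist activity at P2Y purinoceptor 2 (Homo sapiens) (on this read-out lower numbers stand for an effect already at smaller amounts and higher numbers for an effect only at larger amounts of compound), compound 1 gives > 1000 nM, which is a limit of the assay and not a number.
Compound 2: `O=c1ccn([C@@H]2O[C@H](COP(=O)(O)OP(=O)(O)O)[C@@H](O)[C@H]2O)c(=S)[nH]1`. In this assay compound 2 gives > 1000 nM, again a limit rather than a number.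

Compound 2 therefore stands at the limit of > 1000 nM in this assay, at which 2 of the 2 values shown sit, with no number placing it further. Compound 3, `O=c1ccn([C@@H]2O[C@H](COP(=O)(O)O)[C@@H](O)[C@H]2O)c(=S)[nH]1`, differs from compound 2 by a hydrogen atom in place of a group of 4 heavy atoms (3 oxygen, 1 phosphorus; no ring), on an oxygen. Within the data shown here, no measured pair shows a change of this kind, so neither its size nor its direction is known from these data. The expectation is that compound 3 stays where compound 2 stands, which means an expected step that the limit leaves unreadable from compound 2 to compound 3. Compound 3 is thus estimated at 5000 nM, within 1000 nM to 50000 nM, most likely reported again only as a limit.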

Compound 3, half-maximal effective concentration: >= 100000 nM
Compound 3: a limit, no number; the forecaster's own chance of this, stated with the estimate: 90%; middle value at least 20-fold (1.30 log units) from the limit.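

Compound 2 and compound 3 are both reported only as limits, not numbers, so the step between them cannot be read. The compounds shown leave open the concentration at which any of them would produce an effect.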